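The compounds below may be only part of what the source reports. "The series", "measured", "known", "first", "only" and "open" are said of these compounds alone.

Compound 1 `NCCCCn1cc(-c2ccc3cc[nH]c3c2)c(C(F)(F)F)n1` gives 330 nM in an assay on isolated protein for inhibition of Myeloperoxidase (Homo sapiens); a lower number here means a stronger inhibitor, a higher number a weaker inhibitor.
Compound 2 `NC(=O)Cn1cc(-c2ccc3cc[nH]c3c2)c(C(F)(F)F)n1` gives 2000 nM in this assay.
Compound 3 `O=C(O)CCn1cc(-c2ccc3cc[nH]c3c2)c(C(F)(F)F)n1` gives 5200 nM in this assay.

Compound 3 stands highest of the three numbers: compound 2 is nearest, compound 1 furthest, as the steps of a 2.6-fold higher number from compound 2 to compound 3 (0.41 log units; beyond the scatter) and a 16-fold higher number from compound 1 to compound 3 (1.20 log units; beyond the scatter) show. Compound 4 `NC[C@H]1C[C@H](n2cc(-c3ccc4cc[nH]c4c3)c(C(F)(F)F)n2)C1` differs from compound 3 in that (a group of 6 heavy atoms (5 carbon, 1 nitrogen; one four-membered non-aromatic ring of carbon only) in place of a group of 5 heavy atoms (3 carbon, 2 oxygen; no ring), on an aromatic nitrogen). The step that bears most on this is a 16-fold higher number from compound 1 to compound 3 (1.20 log units; beyond the scatter), where a carboxy replaced an amine-bearing chain and the number rose sharply; compound 4 restores a primary amine on a ring-bearing group. The step of a 6.1-fold higher number from compound 1 to compound 2 (0.78 log units; beyond the scatter) likewise rose when the amine was lost. A large fall in this assay is therefore expected, of about a 12-fold lower number from compound 3 to compound 4 (1.06 log units; beyond the scatter). Compound 4 is estimated at 450 nM, within a range from 150 nM to 1400 nM.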

Compound 4, half-maximal inhibitory concentration: 170 nM
Estimate against measurement, compound 4: 2.6-fold (0.42 log units) above; low and high end bracket the measured number.
By their numbers in this assay, from the lowest: compounds 4 and 1 (each within the scatter of the next); then compound 2; then compound 3.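

At this position on the aromatic nitrogen, the four-membered carbon ring carrying an amine gives large steps down from both the 2-carboxyethyl and the amide groups in this assay: a 31-fold lower number from compound 3 to compound 4 (1.49 log units; beyond the scatter) and a 12-fold lower number from compound 2 to compound 4 (1.07 log units; beyond the scatter). The ring can also stand in place of the open amine chain without a change that can be read, a 1.9-fold lower number from compound 1 to compound 4 (0.29 log units; within the scatter). No measurement given here accounts for these steps. Going by these compounds, what stays open is whether the amine or the ring governs the number, which a carboxylic acid on the same four-membered ring would test. A secondary amine on that ring also remains unexplored among the compounds shown.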